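Swapping isopropyl for a halogenated phenyl on the core

The compounds below may be only part of what the source reports. "The series", "measured", "known", "first", "only" and "open" are said of these compounds alone.

Of the compounds shown here, three built on one shared core have been measured in an ADME assay on HepG2 cells (Homo sapiens) for cytotoxicity, read by luminescence, CellTiter-Glo and ATP content, with a stated time of 72 h; on this read-out higher numbers stand for an effect only at larger amounts of compound and lower numbers for an effect already at smaller amounts. Compound 3 `COc1cccc(CNCCCNc2ccnc3cc(CC(C)C)ccc23)c1O` gives 2920 nM. Compound 1 `COc1cccc(CNCCCNc2ccnc3cc(Cc4cccc(C(F)(F)F)c4)ccc23)c1O` gives 1720 nM, and compound 2 `Fc1ccc(Cc2ccc3c(NCCCNCc4ccco4)ccnc3c2)c(Cl)c1` gives 5730 nM. Among these three numbers compound 3 stands second highest, yet all three lie within the scatter of one another, so no order can be read among them.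

Compound 4 `COc1cccc(CNCCCNc2ccnc3cc(Cc4ccc(F)cc4Cl)ccc23)c1O` is not yet measured. It differs from compound 3 in one place: 2-chloro-4-fluorophenyl in place of isopropyl on a saturated chain carbon bound to an aromatic carbon. Among the compounds with values here, the only step measured so far at this same place, a 1.7-fold higher number from compound 1 to compound 3 (0.23 log units; within the scatter), was the opposite kind of exchange, 3-(trifluoromethyl)phenyl giving way to isopropyl, and it stayed within the scatter. Compound 2 carries the same 2-chloro-4-fluorobenzyl group as compound 4, but its other chain end also differs, so its value serves only as a loose reference. The expectation is therefore a 1.2-fold lower number from compound 3 to compound 4 (0.07 log units; within the scatter), a step not beyond the scatter. Compound 4 is estimated at 2500 nM, with a range from 1000 nM to 6500 nM.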

Compound 4, half-maximal effective concentration: 2350 nM
Beside the measured number, compound 4's estimate is 1.1-fold (0.03 log units) above it, and the stated range covers the measured number.
By their numbers in this assay, from the lowest: compounds 1, 4, 3 and 2 (each within the scatter of the next, the first and the last beyond it).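

Putting 2-chloro-4-fluorophenyl in place of isopropyl on a saturated chain carbon bound to an aromatic carbon gives, in this assay, a 1.2-fold lower number from compound 3 to compound 4 (0.09 log units; within the scatter), and putting it in place of 3-(trifluoromethyl)phenyl gives a 1.4-fold higher number from compound 1 to compound 4 (0.14 log units; within the scatter), so neither exchange at this position moves the number beyond the scatter. Within the data shown here, the one new step beyond the scatter, though modest, lies at the other chain end, where 2-hydroxy-3-methoxyphenyl replaces furan-2-yl on a saturated chain carbon bound to an amine nitrogen: a 2.4-fold lower number from compound 2 to compound 4 (0.39 log units; beyond the scatter). Nothing at hand explains either result.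

As far as these compounds go, whether an amine or a carboxylic acid at the first position would also stay within the scatter remains open. So does whether the chain-end step would hold with a group other than 2-chloro-4-fluorophenyl on the core.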